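The compounds below may be only part of what the source reports. "The series", "measured", "known", "first", "only" and "open" are said of these compounds alone.

Of the compounds shown here, three have so far been tested in a functional assay on SMMC-7721 cells (Homo sapiens) for cytotoxicity, read by MTT assay, with a stated time of 4 days; a higher number here means a weaker inhibitor, a lower number a stronger inhibitor. Compound 1 `C=C1C[C@]23C[C@@]1(O)CC[C@@H]2c1cccc(C)c1[C@@H]3Cn1cc(-c2ccc(OC)cc2)nn1` gives only a limit of this assay, > 20000 nM. Compound 3 `C=C1C[C@]23C[C@@]1(O)CC[C@@H]2c1cccc(C)c1[C@@H]3Cn1cc(-c2ccc(F)cc2)nn1` likewise gives only a limit in this assay, > 20000 nM. Compound 2 `C=C1C[C@]23C[C@@]1(O)CC[C@H]2c1ccc(O)c(C)c1[C@@H]3Cn1cc(-c2ccc(F)cc2)nn1` also gives only a limit in this assay, > 20000 nM. The change from compound 3 to compound 1 is methoxy in place of fluoro on an aromatic carbon, and its step that the two limits leave unreadable from compound 3 to compound 1 cannot be read because of the limit of > 20000 nM in this assay, at which 3 of the 3 values shown sit. Compound 4 `C=C1C[C@]23C[C@@]1(O)CC[C@H]2c1ccc(O)c(C)c1[C@@H]3Cn1cc(-c2ccc(OC)cc2)nn1` has not yet been measured. It differs from compound 2 by methoxy in place of fluoro on an aromatic carbon, the same change as that from compound 3 to compound 1, made at the same place; how the core of compound 2 differs from the core of compound 3 is not broken down here. The step from compound 2 to compound 4 is expected to be a step that the limit leaves unreadable from compound 2 to compound 4, an expectation that rests on the unreadable step from compound 3 to compound 1. Compound 4 is thus expected to give about 30000 nM in this assay, between 15000 nM and 80000 nM, most likely again only as a limit.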

Compound 4, half-maximal inhibitory concentration: > 20000 nM
Compound 4 ended at the assay's limit; the forecaster's own chance of this, stated with the estimate: 90%; the middle value is on the limit's open side.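

No new step can be read from compound 2 to compound 4, whose swap of fluoro for methoxy stays unsized in this assay: the limit of > 20000 nM in this assay, at which 4 of the 4 values shown sit. The compounds shown give no number, which leaves open whether going from 4-fluorophenyl to 4-methoxyphenyl, or the difference between the cores, changes the cytotoxicity at all.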